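Inactive chromone amides: a methylphenyl swap on the anilide

The source may report more compounds than this note shows. Statements on the series, on what has been measured and on what is new or still open speak of the compounds shown alone.

Compound 1, `COc1ccc2c(=O)c(/C=C/C(=O)Nc3ccc(Cl)cc3)coc2c1` — > 100000 nM
Compound 2, `Cc1ccc(CNC(=O)/C=C/c2coc3cc(O)ccc3c2=O)cc1` — > 100000 nM

In a functional assay on HeLa cells (Homo sapiens) for inhibition, read by MTT assay, with a stated time of 48 h (on this read-out lower numbers stand for stronger inhibition and higher numbers for weaker inhibition), compound 1 reaches only a limit, > 100000 nM, not a number. Compound 2 likewise gives only a limit, > 100000 nM. Among the measured compounds shown here, compound 1 therefore stands at the limit of > 100000 nM in this assay, at which 2 of the 2 values shown sit, and no step between measured compounds is available. Compound 3, `COc1ccc2c(=O)c(/C=C/C(=O)Nc3cccc(C)c3)coc2c1`, is not yet measured; its change from compound 1 is 3-methylphenyl in place of 4-chlorophenyl on an amide-type nitrogen. No step beyond the scatter is expected in this assay. Compound 3 is expected to give about 100000 nM, between 30000 nM and 300000 nM, a step of a number no higher from compound 1 to compound 3 (the limit leaves the size open) that likely again ends at a limit.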

Compound 3, half-maximal inhibitory concentration: > 100000 nM
Compound 3 gave a limit, no number (the forecaster's own chance of this, stated with the estimate: 80%); the middle value sits exactly at the limit.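

No step can be read from compound 1 to compound 3, as both stand only as limits in this assay. The compounds shown leave open whether 3-methylphenyl in place of 4-chlorophenyl changes inhibition at all.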